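Branching the Chain on a Pyridyl Cyanoguanidine

The source may hold more compounds than are shown below. What is called first, only, known or untested is meant among the compounds shown, and "the series" means these compounds.

Of the compounds shown here, two that share a core have been measured in a functional assay on the whole organism (blood, strain Wistar-Okamoto) with Rattus norvegicus as the target, with a stated time of 5 days; a higher number here means that more compound is needed for the effect, a lower number that less compound is needed. Compound 1 `N#CNC(=N)Nc1cccnc1` is the simpler of the two; in this assay compound 1 needs 50 mg/kg. Compound 2 `CCCC/N=C(\NC#N)Nc1cccnc1` carries a butyl chain on the core; in this assay compound 2 needs 20 mg/kg. Among the two numbers, compound 2 stands lowest, and compound 1 lies beyond the usual scatter above it, so less of compound 2 is needed for the effect than of compound 1.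

Compound 3 `CC(C)CC/N=C(\NC#N)Nc1cccnc1` is the next compound and has not yet been measured. It differs from compound 2 in one place: methyl in place of hydrogen on a saturated chain carbon bound to two saturated chain carbons. Cut one bond further out, this reads as butyl to isobutyl. Within the data shown here, no measured pair shows what such a branching does here, so the expectation rests on compound 2 alone. The step is expected to be small, no further than the scatter in either direction, which puts no change at the digits printed from compound 2 to compound 3 (within the scatter) near nothing. Compound 3 is therefore expected to need about 20 mg/kg, somewhere between 10 mg/kg and 40 mg/kg.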

Compound 3, minimum effective dose: 20 mg/kg
The estimate for compound 3 equals the measured number at the digits printed; measured number inside the range.
By their numbers in this assay, from the lowest: compounds 2 and 3 (each within the scatter of the next); then compound 1.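

In this assay, putting methyl in place of hydrogen on a saturated chain carbon bound to two saturated chain carbons, the change that reads as butyl to isopentyl, gives no change at the digits printed from compound 2 to compound 3 (within the scatter). Among these compounds, this is the first direct reading of a branch on this chain, as the earlier compounds offered no pair that differs in this way. It shows that this chain carbon accepts one added methyl without a change that can be told apart from the usual spread of repeated measurements, though nothing measured alongside these numbers bears on the reason for this result.

Still open, on these data alone, is whether a larger group at this same carbon, such as a phenyl ring or a cyclohexyl ring, or a group of another kind, such as a hydroxyl or an amine, would also leave the number within the scatter. A single step also cannot tell whether a longer chain, such as octyl, would behave like butyl and isopentyl or move the dose needed in either direction.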